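Chain Lengthening on a Shared Core: Propyl to Butyl

A few compounds are considered here, and "the series" means these few. Any claim that something is new, unique, unknown or untested is made for them only; others in the source may bear on it.

Compound 1 `CCCNc1nc(NCc2ccc(C(=O)Nc3ccc(F)cc3)cc2)c2cc(C)ccc2n1` gives 1200 nM in a functional assay on HCT-116 cells (Homo sapiens) for inhibition, read by luminescence and resazurin assay, with a stated time of 3 days; a lower number here means a stronger inhibitor, a higher number a weaker inhibitor.
Compound 2 `CCCNc1nc(NCc2ccc(NC(=O)c3ccc(F)cc3)cc2)c2ccccc2n1` gives 1700 nM in this assay.
Compound 3 `CCCNc1nc(NCc2ccc(C(=O)Nc3ccc(F)cc3)cc2)c2ccccc2n1` gives 1500 nM in this assay.

Of the compounds shown here, three on the shared core have been measured, and their numbers lie close together. Compound 3 sits between the other two: the step of a 1.1-fold lower number from compound 2 to compound 3 (0.05 log units; within the scatter) and the step of a 1.3-fold higher number from compound 1 to compound 3 (0.10 log units; within the scatter) are both within the scatter, so no one of the three can be called stronger or weaker than another on these data.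

Compound 4 `CCCCNc1nc(NCc2ccc(C(=O)Nc3ccc(F)cc3)cc2)c2ccccc2n1` has not yet been measured. It differs from compound 3 in one place: methyl in place of hydrogen on a saturated chain carbon, three bonds along the chain from a nitrogen on an aromatic ring. Neither measured step bears on this chain. The step from compound 1 to compound 3 concerns a methyl on an aromatic carbon of the core, and the step from compound 2 to compound 3 concerns the direction of the amide linkage; both were within the scatter. There is thus no measured guide to what lengthening propyl to butyl does in this assay, and the small spread among compounds 1, 2 and 3 gives no reason to expect a large move in either direction.

Compound 4 is therefore expected to give about 1500 nM, with a range from 700 nM to 3200 nM. The estimate for compound 4 means a step of no change at the digits printed from compound 3 to compound 4 (within the scatter), expected to stay within the scatter.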

Compound 4, half-maximal inhibitory concentration: 1400 nM
Compound 4: middle estimate off by 1.1-fold (0.03 log units), on the high side, within the range that was stated.
By their numbers in this assay, from the lowest: compounds 1, 4, 3 and 2 (each within the scatter of the next).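

In this assay, the chain on the nitrogen of the shared core now has a measured step of its own: the change from propyl to butyl, a methyl in place of hydrogen on a saturated chain carbon, three bonds along the chain from a nitrogen on an aromatic ring, gives a 1.1-fold lower number from compound 3 to compound 4 (0.03 log units; within the scatter) and so lies within the scatter. The earlier compounds shown here had tested only a methyl on an aromatic carbon of the core and the direction of the amide linkage, so this position is the third place on the shared core where a single change stays within the scatter. What can be said of this chain is limited to this one change, and nothing available here accounts for the result.

A single lengthening says nothing about how far the chain can be extended, so a hexyl chain, a branched isobutyl chain or a propyl chain ending in an amine or a carboxylic acid remains an open case. Going by these compounds, it is also open whether butyl gives a similar number on the methyl-bearing core of compound 1 or with the reversed amide of compound 2.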